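From methyl to amino on the phenyl group

The source may report more compounds than this note shows. Statements on the series, on what has been measured and on what is new or still open speak of the compounds shown alone.

Measured in a functional assay on A549 cells (Homo sapiens) for antiproliferative activity, read by MTT assay, with a stated time of 48 h; a lower number here means a stronger inhibitor, a higher number a weaker inhibitor:
Compound 1 `CCOc1ccc(-c2cc3c(cn2)[nH]c(=O)n3-c2cc(OC)c(OC)c(OC)c2)cc1`: 5300 nM
Compound 2 `COc1ccc(-c2cc3c(cn2)[nH]c(=O)n3-c2cc(OC)c(OC)c(OC)c2)cc1C`: 1910 nM

Compound 2, at 1910 nM, holds the lower number of the two. Compound 3 `COc1ccc(-c2cc3c(cn2)[nH]c(=O)n3-c2cc(OC)c(OC)c(OC)c2)cc1N` carries amino in place of methyl on an aromatic carbon, ortho to a methoxy group (amino in place of methyl on an aromatic carbon). Among the compounds with values here, only one measured step bears on this change: a 2.8-fold lower number from compound 1 to compound 2 (0.44 log units; beyond the scatter), a modest step made on the same phenyl group. Within the data shown here, no measured compound carries amino, so the direction rests on little evidence. A lower number is tentatively expected, with an estimated step of a 3.2-fold lower number from compound 2 to compound 3 (0.50 log units; beyond the scatter). Compound 3 is estimated at 600 nM, with an expected range of 100 nM to 2500 nM.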

Compound 3, half-maximal inhibitory concentration: 1140 nM
The estimate for compound 3 lay 1.9-fold (0.28 log units) below the measured number; the range from low to high includes it.
By their numbers in this assay, from the lowest: compounds 3 and 2 (each within the scatter of the next); then compound 1.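

In this assay, amino in place of methyl on this aromatic carbon, ortho to a methoxy group, gives a 1.7-fold lower number from compound 2 to compound 3 (0.22 log units; within the scatter) and so does not separate the two groups at this position. The 3-amino-4-methoxyphenyl group also shows a 4.6-fold lower number from compound 1 to compound 3 (0.67 log units; beyond the scatter) against the 4-ethoxyphenyl group, so this second group on the same carbon likewise stands clear of compound 1. Nothing measured here accounts for these numbers. As far as these compounds go, what remains open is whether a hydroxyl group, a chlorine atom or a dimethylamino group on this carbon would move the number beyond the scatter.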